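Swapping Chloro for Fluoro on Compound 1

The compounds below may be only part of what the source reports. "The series", "measured", "known", "first", "only" and "open" are said of these compounds alone.

Compound 1 `Cc1ccc(COc2ccc(C(=O)/C=C/c3ccc(Cl)cc3)cc2)cc1` was tested in a functional assay on HCT-116 cells (Homo sapiens) for inhibition, read by sulforhodamine B assay, with a stated time of 3 days (a lower number here means a stronger inhibitor of growth, a higher number a weaker inhibitor of growth), and returned only a limit, > 50000 nM, rather than a number. Two related compounds do return numbers: compound 2 `O=C(/C=C/c1ccccc1Cl)c1ccc(OCc2ccccc2)cc1` gives 14900 nM in this assay, and compound 3 `O=C(/C=C/c1cccc([N+](=O)[O-])c1)c1ccccc1` gives 4470 nM. Among the three values shown, compound 1 stands at the weak end, since it sits at the limit of > 50000 nM in this assay, at which 1 of the 3 values shown sits. Within the data shown here, no two of the measured compounds differ in only one place, so no measured step is available, and of compounds 2 and 3 nothing more can be said than what their two values show.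

Compound 4 `Cc1ccc(COc2ccc(C(=O)/C=C/c3ccc(F)cc3)cc2)cc1` has not yet been measured. It differs from compound 1 by fluoro in place of chloro on an aromatic carbon. The chloro leaves and a fluoro enters, one heavy atom for one heavy atom, and no ring, donor, acceptor or charge changes. Among the measured compounds shown here, with no measured step to follow, the expectation rests on where compound 1 stands: the step is expected to be small, none beyond the scatter in either direction, so compound 4 is expected to remain weak and may again return only a limit. For compound 4 the estimate in this assay is 60000 nM, between 20000 nM and 150000 nM. The step this estimate implies, a step that the limit leaves unreadable from compound 1 to compound 4, is expected to be negligible.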

Compound 4, concentration for 50% growth inhibition: > 50000 nM
Compound 4 was reported as a limit (the forecaster's own chance of this, stated with the estimate: 65%); the middle value is on the limit's open side.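

In this assay compound 4 gives > 50000 nM, a limit and not a number. Compound 1 also gave only a limit, so no step from compound 1 to compound 4 can be read: the limit of > 50000 nM in this assay, at which 2 of the 4 values shown sit.

The compounds shown leave open whether fluoro in place of chloro changes growth inhibition in this assay at all.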